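Compound 3: a group swap at the cytotoxicity limit

A few compounds are considered here, and "the series" means these few. Any claim that something is new, unique, unknown or untested is made for them only; others in the source may bear on it.

In an ADME assay on HEK293 cells (Homo sapiens) for cytotoxicity, read by CellTiter-Glo and resazurin assay, with a stated time of 72 h (a higher number here means that more compound is needed for the effect, a lower number that less compound is needed), compound 2 `CCOC(=O)CCCCCOc1cccc(CN(C(=O)c2ccc(-c3ccc4ccccc4c3)cc2)C(C)C)c1` gives > 26000 nM as a limit of the assay, not a number. Compound 1 `CCOC(=O)CCCCCOc1cccc(CN(C(=O)c2ccc(-c3cccc(NC(C)=O)c3)cc2)C(C)C)c1` gives > 26000 nM as a limit too. Compound 3 `CCOC(=O)CCCCCOc1cccc(CN(C(=O)c2ccc(-c3cccc(OC(C)C)c3)cc2)C(C)C)c1` carries 3-isopropoxyphenyl in place of naphthalen-2-yl on an aromatic carbon. Going by the values given here, the one measured step at this place is a step that the two limits leave unreadable from compound 1 to compound 2 and has no readable size, with the limit of > 26000 nM in this assay, at which 2 of the 2 values shown sit, as the whole record. No step beyond the scatter is therefore expected in this assay for this change. The expected change is a number no higher from compound 2 to compound 3 (the limit leaves the size open) (an estimate). Compound 3 is expected at 26000 nM (estimated range 13000 nM to 40000 nM).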

Compound 3, half-maximal effective concentration: > 26000 nM
Compound 3 gave a limit, no number (the forecaster's own chance of this, stated with the estimate: 80%); the middle value sits exactly at the limit.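

No step can be read among compound 1, compound 2 and compound 3, as each gives only a limit and no number: the limit of > 26000 nM in this assay, at which 3 of the 3 values shown sit.

The compounds shown leave open at what concentration each is cytotoxic, and whether the three groups on this aromatic carbon differ at all.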